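Shortening the Amide Chain of Compound 1

This account rests on a few compounds, and the source may have more. Where it says the series, first, only, none or still open, it means among the compounds named here.

Compound 1 (`CCCCCCCCCCNC(=O)C1C(C(=O)O)[C@@H]2CC[C@H]1O2`) and compound 2 (`CCOC(=O)c1cn[nH]c1NC(=O)C1C(C(=O)O)[C@@H]2CC[C@H]1O2`) share a core and have both been tested in an ADME assay on BE(2)-C cells (Homo sapiens) for cytotoxicity, read by MTT assay, with a stated time of 72 h; on this read-out lower numbers stand for stronger inhibition of growth and higher numbers for weaker inhibition of growth. In this test compound 1 gives 10000 nM. Within the data shown here, compound 2 gives 10000 nM, so the two stand level, and compound 1 has no separation from the only other measured compound.

The next compound to be tested is compound 3 (`CCCCNC(=O)C1C(C(=O)O)[C@@H]2CC[C@H]1O2`). It departs from compound 1 by one change, hydrogen in place of hexyl on a saturated chain carbon, four bonds along the chain from an amide-type nitrogen.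

Among the measured compounds shown here, no measured step between closely matched compounds is available to gauge this change. For the measured compounds named here, the only guide is that compound 2 reads 10000 nM in this assay, the same as compound 1, even though the two differ in what the amide-type nitrogen carries. No shift beyond the scatter is therefore expected in this assay, and the estimated step is a 1.2-fold higher number from compound 1 to compound 3 (0.08 log units; within the scatter). The estimated value for compound 3 is 12000 nM, with an expected range from 5000 nM to 30000 nM.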

Compound 3, concentration for 50% growth inhibition: 10000 nM
Compound 3: the middle estimate sits 1.2-fold (0.08 log units) above what was measured; low and high end bracket the measured number.
By their numbers in this assay, from the lowest: compounds 1, 2 and 3 (each within the scatter of the next).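

In this assay, putting hydrogen in place of hexyl on a saturated chain carbon, four bonds along the chain from an amide-type nitrogen, gives a step that reads no change at the digits printed from compound 1 to compound 3 (within the scatter). Among these compounds, this is the first measured step between closely matched compounds, and it shows that in this test the amide chain of compound 1 can lose its hexyl portion without any separation from compound 1 at the digits printed. No measurement accompanying this result speaks to why the reading holds across the change.

The compounds shown leave open whether a chain longer than that of compound 1, or a chain of either length ending in an amine, a hydroxyl group or a carboxylic acid, would separate from compound 1 and compound 3 in this assay. Among the compounds shown here, they also leave open whether shortening the chain further, to a methyl or ethyl group on the amide-type nitrogen, would keep the reading level with that of compound 3, so the single step so far describes only this one exchange.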